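The source may report more compounds than this note shows. Statements on the series, on what has been measured and on what is new or still open speak of the compounds shown alone.

Within the data shown here, in a toxicity assay on the whole organism (strain Icem-CET (SPF Caw)) for cytotoxicity, with Mus musculus as the target (a higher number here means that more compound is needed for the effect, a lower number that less compound is needed), compound 3 `C=CCNC(=O)/C(C)=C(/C)c1ccc(Cl)cc1` gives 180 mg/kg, the lowest of the three numbers measured so far, though the gaps to the other two fall within the scatter of repeated measurements. Compound 2 `C/C(C(=O)NC1CC1)=C(\C)c1ccc(C)cc1` gives 280 mg/kg in this assay. Compound 1 `C/C(C(=O)NC1CC1)=C(\C)c1ccc(Br)cc1` gives 300 mg/kg in this assay. Among the measured compounds shown here, the one step between measured compounds that differ in a single place, a 1.1-fold lower number from compound 1 to compound 2 (0.03 log units; within the scatter), concerns a group on the aromatic ring and changes nothing at the amide nitrogen, so it does not bear directly on the change examined here.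

Compound 4 `C/C(C(=O)NC1CC1)=C(\C)c1ccc(Cl)cc1` differs from compound 3 in one place: cyclopropyl in place of allyl on an amide-type nitrogen. For the measured compounds named here, no measured pair shows this exact exchange, so the expectation can only lean on the two compounds that already carry cyclopropyl on the amide nitrogen. Since compound 1 gives 300 mg/kg and compound 2 gives 280 mg/kg in this assay, and both lie within the scatter of the number for compound 3, compound 4 is expected to land in the same region, with at most a small rise. The expected step is a 1.4-fold higher number from compound 3 to compound 4 (0.14 log units; within the scatter), which stays within the scatter. Compound 4 is therefore estimated at 250 mg/kg, with a likely range from 140 mg/kg to 450 mg/kg.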

Compound 4, dose for half-maximal effect: 170 mg/kg
Compound 4: middle estimate off by 1.5-fold (0.17 log units), on the high side; the measured number falls inside the stated range.
By their numbers in this assay, from the lowest: compounds 4, 3, 2 and 1 (each within the scatter of the next).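

In this assay, among these compounds, the step of a 1.1-fold lower number from compound 3 to compound 4 (0.02 log units; within the scatter) is the first direct test of cyclopropyl in place of allyl on an amide-type nitrogen, and it lies within the scatter, so closing this open chain into a ring leaves no readable mark on the dose. With cyclopropyl held fixed, compound 4 also completes a set of three groups on the aromatic carbon: a 1.6-fold lower number from compound 2 to compound 4 (0.22 log units; within the scatter) and a 1.8-fold lower number from compound 1 to compound 4 (0.25 log units; within the scatter) both lie within the scatter, so chloro cannot be told apart from methyl or bromo at this position in this assay. No measurement of any property of these groups accompanies the doses, which leaves them without an explanation.

All four compounds sit so close together that no change shown so far moves the dose beyond the scatter, so it remains open whether anything at these two places can do so. A longer chain or a chain bearing an amine on the amide-type nitrogen, or a carboxylic acid on the aromatic carbon, would test whether these places respond at all.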